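This account rests on a few compounds, and the source may have more. Where it says the series, first, only, none or still open, it means among the compounds named here.

Measured in an ADME assay on microsomes from liver (Mus musculus) for metabolic stability, read by HPLC, with a stated time of 30 min; on this read-out lower numbers stand for a less stable compound and higher numbers for a more stable compound:
compound 1 `O=C(Nc1ccc(-n2cccn2)cc1)C(=O)c1c[nH]c2ccccc12`: 93.6%
compound 2 `COc1ccc(NC(=O)C(=O)c2c[nH]c3cc(Cl)ccc23)cc1`: 87.3%
compound 3 `Cc1ccc(NC(=O)C(=O)c2c[nH]c3cc(Cl)ccc23)cc1`: 85.6%

All three compounds keep most of their material over the test, and their values lie within the usual scatter of one another. Compound 3, at 85.6%, therefore cannot be told apart from the other two on these numbers.

The next compound to be tested is compound 4 `O=C(Nc1ccc(-n2cccn2)cc1)C(=O)c1c[nH]c2cc(Cl)ccc12`. The change from compound 3 is 1H-pyrazol-1-yl in place of methyl on an aromatic carbon. In words, 1H-pyrazol-1-yl stands in place of methyl on an aromatic carbon, para to a large group.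

For the measured compounds named here, one measured step bears directly on this place: a number 1.7 percentage points lower from compound 2 to compound 3 (within the scatter), where methyl replaces methoxy. That step is small and lies within the scatter, but it covers only a much smaller swap than this one. Compound 1 offers a second clue, as it already carries 1H-pyrazol-1-yl, though on a core without chlorine, and it gives 93.6%. Neither observation points to a large shift in this assay, so no change beyond the scatter is expected.

The estimated change is a number 2.4 percentage points higher from compound 3 to compound 4 (within the scatter).

Compound 4 is expected to give about 88%, with an expected range from 78% to 97%.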

Compound 4, percent of the compound remaining: 96.7%
Compound 4: middle estimate off by 8.7 percentage points, on the low side, and the stated range covers the measured number.
By their numbers in this assay, from the lowest: compounds 3, 2, 1 and 4 (each within the scatter of the next, the first and the last beyond it).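

In this assay, for the compounds shown here, putting 1H-pyrazol-1-yl in place of methyl on the aromatic carbon para to a large group gives a number 11.1 percentage points higher from compound 3 to compound 4 (beyond the scatter), the first step in this set that can be told apart from ordinary repeat variation, which shows that the group at this position can shift the read-out, if only modestly. The picture depends on which group is replaced, since 1H-pyrazol-1-yl in place of methoxy gives a number 9.4 percentage points higher from compound 2 to compound 4 (within the scatter), so these two groups cannot be separated on this measure, even though the methyl and methoxy compounds could not be separated either. With 1H-pyrazol-1-yl already in place, chloro in place of hydrogen gives a number 3.1 percentage points higher from compound 1 to compound 4 (within the scatter), so adding the chloro brings no change that can be distinguished from variation between repeats.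

No supporting measurement is available to explain why the step from methyl appears. From the compounds shown here alone, it also remains open how this position would respond to a group of another kind, such as an amine, a carboxylic acid or a longer chain, and whether the modest step from methyl would carry over to other cores.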